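The compounds below may be only part of what the source reports. "The series", "measured", "known", "first", "only" and "open" are said of these compounds alone.

Measured so far:
- compound 1 `COc1ccc(NC(=S)NC2CC(C)(C)Oc3ccc(Br)cc32)cc1`: 33000 nM
- compound 2 `CC1(C)CC(NC(=S)Nc2cccc(C#N)c2)c2cc(Br)ccc2O1`: 9000 nM
- compound 3 `CC1(C)CC(NC(=S)Nc2cccc(C#N)c2)c2cc(F)ccc2O1`: 39000 nM

In a functional assay on T98G cells (Homo sapiens) for inhibition, read by MTT assay, with a stated time of 72 h (a lower number here means a stronger inhibitor, a higher number a weaker inhibitor), compound 1 gives 33000 nM. This number cannot be told apart from that of compound 3, at 39000 nM, since the two lie within the usual scatter of each other. Compound 2 stands clearly lower, at 9000 nM.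

The unmeasured compound 4 `CC1(C)CC(NC(=S)Nc2ccc([N+](=O)[O-])cc2)c2cc(Br)ccc2O1` differs from compound 1 in one place: nitro in place of methoxy on an aromatic carbon. Nitro takes the place of methoxy on an aromatic carbon, para to a large group, and the bromo stays.

Two measured steps are available. The change of a 4.3-fold higher number from compound 2 to compound 3 (0.64 log units; beyond the scatter) swaps the bromo, which is untouched here, so it says little about compound 4. The closer guide is a 3.7-fold lower number from compound 1 to compound 2 (0.56 log units; beyond the scatter), where the 4-methoxyphenyl is also replaced and the bromo also stays, although the incoming group is a different one. A step of similar or somewhat smaller size towards lower numbers is therefore expected. The estimate amounts to an expected 2.8-fold lower number from compound 1 to compound 4 (0.44 log units; beyond the scatter). This rests on one step only, so the range is kept wide. For compound 4 the estimated value is 12000 nM, with an expected range from 4000 nM to 35000 nM.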

Compound 4, half-maximal inhibitory concentration: 5000 nM
Compound 4: the middle estimate sits 2.4-fold (0.38 log units) above what was measured; measured number inside the range.
By their numbers in this assay, from the lowest: compounds 4 and 2 (each within the scatter of the next); then compounds 1 and 3 (each within the scatter of the next).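

In this assay, swapping methoxy for nitro gives a 6.6-fold lower number from compound 1 to compound 4 (0.82 log units; beyond the scatter) and is beyond the usual scatter. Here the new group stays on the same aromatic carbon, para to a large group, and the bromo is untouched, so this step isolates a change of group alone, whereas the earlier change from 4-methoxyphenyl to 3-cyanophenyl altered both the group and its place on the ring. The printed values of compound 4, 5000 nM, and compound 2, 9000 nM, lie within the scatter of each other, and nothing measured here explains why replacing methoxy with nitro lowers the number.

On these data alone, it remains open how other groups at this same place, such as an amine, a carboxylic acid or a longer chain like butoxy, would change the number, so a single pair cannot yet define a trend for this position. Also unresolved is whether the nitro step would keep its size with fluoro in place of bromo, the change that raised the number for the 3-cyanophenyl compounds.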